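Hydroxy for iodo on the aryl ring of compound 2

This account rests on a few compounds, and the source may have more. Where it says the series, first, only, none or still open, it means among the compounds named here.

Measured compounds:
compound 1 `CCCN(CCC)c1cc(C)nc2c(-c3ncc(N(CC)CC)cc3C)c(C)nn12` 13 nM
compound 2 `CCCN(CCC)c1cc(C)nc2c(-c3ncc(I)cc3C)c(C)nn12` 6.6 nM

In an assay on isolated protein for binding affinity to corticotropin-releasing factor receptor 1 (Homo sapiens) (on this read-out lower numbers stand for stronger inhibition and higher numbers for weaker inhibition), compound 1 gives 13 nM and compound 2 gives 6.6 nM. Within the data shown here, the one measured step, a 2.0-fold lower number from compound 1 to compound 2 (0.29 log units; within the scatter), exchanges groups at one aromatic carbon and stays within the scatter. Compound 2 therefore holds the lower of the two numbers, but compound 1 sits within the scatter of it, so no ranking between the two is claimed.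

Compound 3 `CCCN(CCC)c1cc(C)nc2c(-c3ncc(O)cc3C)c(C)nn12` is the next variation at the same carbon: hydroxy in place of iodo on an aromatic carbon. Among the measured compounds shown here, only one step bears on this position, a 2.0-fold lower number from compound 1 to compound 2 (0.29 log units; within the scatter), and it was within the scatter; neither measured compound carries a hydroxy group, so nothing in the data speaks to this exact change. The expectation rests on that single step alone: a step from compound 2 to compound 3 of modest size, a 2.3-fold higher number from compound 2 to compound 3 (0.36 log units; beyond the scatter), is expected in this assay, with the direction uncertain and a wide range allowed. Compound 3 is estimated at 15 nM, between 5 nM and 50 nM.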

Compound 3, inhibition constant: 530 nM
The estimate for compound 3 lay 35-fold (1.55 log units) below the measured number, and the stated range ends below it.
By their numbers in this assay, from the lowest: compounds 2 and 1 (each within the scatter of the next); then compound 3.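

In this assay, this carbon turns out not to be indifferent to its substituent: the exchange of diethylamino for iodo stayed within the scatter (a 2.0-fold lower number from compound 1 to compound 2 (0.29 log units; within the scatter)), whereas hydroxy in place of iodo gives a large step (an 80-fold higher number from compound 2 to compound 3 (1.90 log units; beyond the scatter)), and hydroxy in place of diethylamino gives one of similar scale (a 41-fold higher number from compound 1 to compound 3 (1.61 log units; beyond the scatter)). Heavy-atom count alone does not sort these numbers, since iodo and hydroxy each count 1 heavy atom yet lie far apart, while hydroxy brings a hydrogen-bond donor and a hydrogen-bond acceptor that iodo lacks. Nothing available here accounts for the large step, so the association with hydroxy remains an observation on three compounds and no more.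

Open, from the compounds shown here alone, is whether the large step belongs to hydroxy specifically or extends to other small groups at this carbon, and a methoxy group, a primary amine or a fluorine atom would each test that in a different way. Also open, going by these compounds, is how a carboxylic acid or a longer ether chain would read at the same carbon, and whether the step from iodo to hydroxy would keep its size on a different core.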